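Swapping a Chloro for a Hydroxy on a Side Ring

The source may report more compounds than this note shows. Statements on the series, on what has been measured and on what is new or still open speak of the compounds shown alone.

Of the compounds shown here, three have been tested so far, and a fourth awaits its turn. Compound 1 has the structure `N#Cc1c(-c2ccc(Cl)cc2)nc(SCC(=O)Nn2c(COc3ccc(Cl)cc3Cl)nc3ccccc3c2=O)[nH]c1=O`, and compound 2, `N#Cc1c(-c2ccc(O)cc2)nc(SCC(=O)Nn2c(COc3ccc(Cl)cc3Cl)nc3ccccc3c2=O)[nH]c1=O`, is built on the same core. In a functional assay on the whole organism (strain albino) for inhibition, with Rattus norvegicus as the target, read by paw edema, with stated times of 1 h and 0.5 h, at a dose of 100 mg/kg by the oral route (on this read-out higher numbers stand for more inhibition at the one dose given (going by the name of the read-out) and lower numbers for less inhibition), compound 1 gives 61.5%, and compound 2 gives 61.5%. The only structural difference between them is hydroxy in place of chloro on an aromatic carbon, and the step of no change at the digits printed from compound 1 to compound 2 (within the scatter) shows that this swap left the read-out where it was.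

Compound 3, `N#Cc1c(Nc2ccc(Cl)cc2)nc(SCC(=O)Nn2c(COc3ccc(Cl)cc3Cl)nc3ccccc3c2=O)nc1-c1ccc(Cl)cc1`, rests on a different core; the difference between the two cores is not broken down here. In this assay compound 3 gives 46.2%, the lowest of the three numbers, and its gap to both compound 1 and compound 2 lies beyond the usual scatter.

Compound 4, `N#Cc1c(Nc2ccc(O)cc2)nc(SCC(=O)Nn2c(COc3ccc(Cl)cc3Cl)nc3ccccc3c2=O)nc1-c1ccc(Cl)cc1`, has not yet been measured. It differs from compound 3 by hydroxy in place of chloro on an aromatic carbon, and the place of the change is the same as in the pair of compound 1 and compound 2, so this is the same change made on another core. Since the earlier step of no change at the digits printed from compound 1 to compound 2 (within the scatter) showed no movement, the step of a number 0.2 percentage points lower from compound 3 to compound 4 (within the scatter) is expected to be similarly small. On that basis compound 4 is estimated to give 46% in this assay, with a likely range from 32% to 60%, an expectation that rests on a single earlier pair and therefore carries real uncertainty.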

Compound 4, a percentage reported as inhibition, in the whole organism at one dose (the size of the read-out at that dose, not a potency): 71.2%
Beside the measured number, compound 4's estimate is 25.2 percentage points below it, outside the stated range (above it).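

The chloro-to-hydroxy swap did not behave the same way on the two cores in this assay: the same change on two cores in this assay, no change at the digits printed (within the scatter) from compound 1 to compound 2 and a number 25 percentage points higher (beyond the scatter) from compound 3 to compound 4, 25 percentage points apart, beyond the scatter of two such steps The step on the second core, a number 25 percentage points higher from compound 3 to compound 4 (beyond the scatter), shows that a result seen on one core in this series cannot simply be carried over to another, even when the same atom is exchanged on the same kind of ring. It does not show why the two cores part ways or which structural difference is responsible, and two pairs are too few to support a general rule about either core; the changed ring is named as 4-chlorophenyl to 4-hydroxyphenyl in one pair and as (4-chlorophenyl)amino to (4-hydroxyphenyl)amino in the other, but these pairs alone cannot separate that amino link from the other differences between the cores.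

The compounds shown leave open how other groups at this ring position, such as an amine, a methoxy group or a carboxylic acid, would fare on each core. They also leave open whether the gap between the two steps would hold at doses other than the single one used here.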